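The compounds below may be only part of what the source reports. "The series", "measured", "known", "first", "only" and "open" are said of these compounds alone.

Measured so far in a functional assay on HeLa cells (Homo sapiens) for cytotoxicity, read by MTT assay, with a stated time of 2 days, tested at 10 uM; a lower number here means a stronger effect, a higher number a weaker effect of the compound at the concentration tested:
- compound 1, `COc1ccc(-c2cc3cc(-c4ccccc4)cc(C(C)=O)c3[nH]2)cc1`: 51.6%
- compound 2, `COc1ccc(-c2cc3cc(-c4ccc(F)cc4)cc(C(C)=O)c3[nH]2)cc1`: 52%
- compound 3, `CC(=O)c1cc(/C=C/c2ccccc2)cc2cc(-c3ccc(F)cc3)[nH]c12`: 51.9%

The three measured compounds sit close together in this assay; the value of compound 3 and that of compound 2 differ by a margin that lies within the usual scatter, and the same holds for compound 3 against compound 1. How the core of compound 3 differs from the core of compound 1 is not broken down here.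

Compound 4, `CC(=O)c1cc(/C=C/c2ccc(F)cc2)cc2cc(-c3ccc(F)cc3)[nH]c12`, has not been measured in this assay. It stands to compound 3 as compound 2 stands to compound 1: the change is fluoro in place of hydrogen on an aromatic carbon, and the measured pair shows (fluoro in place of hydrogen on an aromatic carbon). The place of the change reads the same in both pairs, so this is the same change; cut one bond further out, compound 3 to compound 4 also reads 2-phenylethenyl to 2-(4-fluorophenyl)ethenyl. The measured step for this change is a number 0.4 percentage points higher from compound 1 to compound 2 (within the scatter).

Among the measured compounds shown here, for compound 4 the expectation is a step of about the same size, a number 0.1 percentage points higher from compound 3 to compound 4 (within the scatter), which rests on the single measured example of this change, a number 0.4 percentage points higher from compound 1 to compound 2 (within the scatter), and on compound 3 giving 51.9%. The estimate for compound 4 in this assay is accordingly 52%, expected to fall between 44% and 60%.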

Compound 4, a percentage reported as activity, at one concentration (the size of the read-out at that concentration, not a potency): 41.9%
The estimate for compound 4 lay 10.1 percentage points above the measured number; the whole stated range lies above it.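

Fluoro in place of hydrogen on an aromatic carbon has now been read on two cores in this assay, and on the core of compound 3 the result is a number 10 percentage points lower from compound 3 to compound 4 (within the scatter). Set beside the earlier step, the two readings do not separate: the same change on two cores in this assay, a number 0.4 percentage points higher (within the scatter) from compound 1 to compound 2 and a number 10 percentage points lower (within the scatter) from compound 3 to compound 4, 10.4 percentage points apart, within the scatter of two such steps Carrying this change from one core to another in this series is therefore not contradicted by these two pairs, but neither step stands clear of the scatter, so they do not show that the change has a real effect of its own on either core, and they do not show that its effect is the same on both or depends on the core. Among the compounds shown here, with only two pairs, each read at a single concentration, nothing about potency or about the wider series follows from them.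

Still open, going by these compounds, is whether an amine or a carboxylic acid in place of the fluoro on the 2-(4-fluorophenyl)ethenyl group would give a step beyond the scatter in this assay. Also open, on these data alone, is how a longer chain in place of the 2-phenylethenyl group would read on the same core.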